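This account rests on a few compounds, and the source may have more. Where it says the series, first, only, none or still open, it means among the compounds named here.

Measured so far in an ADME assay on CCRF-CEM cells (Homo sapiens) for antiproliferative activity, with a stated time of 48 h; on this read-out lower numbers stand for stronger inhibition and higher numbers for weaker inhibition
compound 1 `C=C(Br)C(=O)Nc1ccc(C(=O)/C=C/c2ccccc2)cc1` gives 1500 nM
compound 2 `C=C(Br)C(=O)Nc1ccc(C(=O)/C=C/c2cccc(OC)c2)cc1` gives 1800 nM
compound 3 `C=C(Br)C(=O)Nc1ccc(C(=O)/C=C/c2ccccc2OC)cc1` gives 580 nM

Compound 2 (1800 nM) sits level with its nearest neighbour (a 1.2-fold higher number from compound 1 to compound 2 (0.08 log units; within the scatter)) and apart from its furthest (a 3.1-fold lower number from compound 2 to compound 3 (0.49 log units; beyond the scatter)). Compound 4 `COc1cccc(/C=C/C(=O)c2ccc(N)cc2)c1` is reached through hydrogen in place of (1-bromoethenyl)carbonyl on a nitrogen on an aromatic ring in words, hydrogen in place of (1-bromoethenyl)carbonyl on a nitrogen on an aromatic ring.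

The measured steps offer only weak guidance. Each concerns a methoxy group, the other being a 2.6-fold lower number from compound 1 to compound 3 (0.41 log units; beyond the scatter) and none touches this nitrogen. Within the data shown here, every measured compound carries the (1-bromoethenyl)carbonyl, so the series holds no direct precedent and the size below is a judgement. In this assay a step well beyond the scatter is expected, toward weaker inhibition, and the estimated size is an 8.3-fold higher number from compound 2 to compound 4 (0.92 log units; beyond the scatter) with wide uncertainty. For compound 4 the expected value is 15000 nM within an estimated range of 4000 nM to 50000 nM for the measurement to come.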

Compound 4, half-maximal inhibitory concentration: 23000 nM
For compound 4 the middle estimate is 1.5-fold (0.19 log units) below the measured one; measured number inside the range.
By their numbers in this assay, from the lowest: compound 3; then compounds 1 and 2 (each within the scatter of the next); then compound 4.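

In this assay, replacing the (1-bromoethenyl)carbonyl on the nitrogen with hydrogen, which leaves a plain amino group, gives a 13-fold higher number from compound 2 to compound 4 (1.11 log units; beyond the scatter). Among these compounds, this is the first step at this nitrogen and the first of large size, whereas the earlier steps, all involving the methoxy group, were modest or within the scatter; on this single pair, the change at the nitrogen outweighs those changes. No measurement available here bears on the reason for this loss.

On these data alone, it remains open whether the same change costs as much with the 2-methoxyphenyl of compound 3 or the unsubstituted phenyl of compound 1. Also open, as far as these compounds go, is which part of the departing group counts: an acetyl or a plain acryloyl on this nitrogen would separate the contribution of the carbonyl from that of the bromine.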